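The source may report more compounds than this note shows. Statements on the series, on what has been measured and on what is new or still open speak of the compounds shown alone.

For the measured compounds named here, in a functional assay on MCF7 cells (Homo sapiens) for antiproliferative activity, read by sulforhodamine B assay, with a stated time of 48 h (a higher number here means a weaker inhibitor of growth, a lower number a stronger inhibitor of growth), compound 1 (`O=C1/C(=C/c2ccc3ccccc3c2)CNC/C1=C\c1ccc2ccccc2c1`) gives 29800 nM as the only numeric value so far. Compound 2 (`Cc1ccc(/C=C2\CNC/C(=C\c3ccc(C)s3)C2=O)s1`) gives > 100000 nM as a limit of the assay, not a number. Compound 3 (`C=CC(=O)N1C/C(=C\c2ccc3ccccc3c2)C(=O)/C(=C/c2ccc3ccccc3c2)C1`) carries vinylcarbonyl in place of hydrogen on an amine nitrogen in a ring of the core of compound 1 (vinylcarbonyl in place of hydrogen on an amine nitrogen in a ring). Going by the values given here, no measured step covers this change, so the direction is a tentative expectation: moderately stronger growth inhibition in this assay, with a wide margin. The expected change is a 3.7-fold lower number from compound 1 to compound 3 (0.57 log units; beyond the scatter) in size. The value estimated for compound 3 is 8000 nM (1500 nM to 40000 nM).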

Compound 3, concentration for total growth inhibition: 5300 nM
Compound 3: the middle estimate sits 1.5-fold (0.18 log units) above what was measured; measured number inside the range.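

In this assay, for the compounds shown here, the amine nitrogen in the ring of compound 1 tolerates substitution: vinylcarbonyl there gives a 5.6-fold lower number from compound 1 to compound 3 (0.75 log units; beyond the scatter) as the first readable step. The earlier compounds shown here offered no step at this nitrogen, or any other single change. Nothing shown gives a cause for this step.

Still open, as far as these compounds go, is whether the gain needs vinylcarbonyl itself, or whether a saturated propanoyl or a plain acetyl on the same nitrogen would do the same. Also open, from the compounds shown here alone, is whether it carries over to other aryl groups on the shared core.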